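Shortening the hydroxyalkyl chain on a shared amidine core

The source may hold more compounds than are shown below. What is called first, only, known or untested is meant among the compounds shown, and "the series" means these compounds.

Three compounds have been measured in a functional assay on MDA-MB-231 cells (Homo sapiens) for cytotoxicity, read by MTT assay, with a stated time of 72 h, tested at 5 uM, in the absence of a further agent; on this read-out higher numbers stand for a weaker effect at the one concentration tested and lower numbers for a stronger effect:

compound 1 `CC1(C)CC(=O)Nc2ccc(Cl)cc21`: 81.7%
compound 2 `CC1(C)CC(=S)Nc2ccc(Cl)cc21`: 94.3%
compound 3 `CC1(C)CC(NCCCCO)=Nc2ccc(Cl)cc21`: 84.9%

Compound 3 stands second highest of these three numbers. Its nearest neighbour is compound 1 and its furthest is compound 2, yet both gaps lie within the scatter of repeated measurements, so the three compounds cannot be told apart on this read-out.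

Compound 4 `CC1(C)CC(NCCCO)=Nc2ccc(Cl)cc21` differs from compound 3 in one place: hydroxy in place of hydroxymethyl on a saturated chain carbon, three bonds along the chain from an amine nitrogen. Among the measured compounds shown here, no step between measured compounds is available, so the size of this change must be judged from the structural change alone. Given that all measured compounds sit together, the step in this assay is expected to be small, in no particular direction, estimated at a number 1.1 percentage points higher from compound 3 to compound 4 (within the scatter). Compound 4 is therefore expected to give about 86%, with a range from 74% to 98%.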

Compound 4, a percentage reported as activity, at one concentration (the size of the read-out at that concentration, not a potency): 84.2%
Beside the measured number, compound 4's estimate is 1.8 percentage points above it; low and high end bracket the measured number.
By their numbers in this assay, from the lowest: compounds 1, 4, 3 and 2 (each within the scatter of the next, the first and the last beyond it).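

Cutting the chain from 4-hydroxybutyl to 3-hydroxypropyl gives the first step read at this position: in this assay it is a number 0.7 percentage points lower from compound 3 to compound 4 (within the scatter). At this length, then, hydroxy in place of hydroxymethyl produces no change that this read-out can resolve. No measurement here offers an explanation for this result.

On these data alone, it remains open whether a 2-hydroxyethyl chain, a longer chain or an amine in place of the hydroxy would stand apart from compound 3 beyond the scatter.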